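Amino for cyano on the sulfonyl pyridine ring

The source may report more compounds than this note shows. Statements on the series, on what has been measured and on what is new or still open speak of the compounds shown alone.

Measured compounds in an ADME assay on microsomes from liver (Mus musculus) for metabolic stability, read by LC-MS, using NADPH, tested at 10 uM; on this read-out lower numbers stand for a shorter-lived compound and higher numbers for a longer-lived compound:
- compound 1, `O=C(NCc1ccc(F)cc1)c1ccc(N2CCN(S(=O)(=O)c3ccccc3C(F)(F)F)CC2)nn1`: 0.517 h
- compound 2, `O=C(NCc1ccc(F)cc1)c1ccc(N2CCN(S(=O)(=O)c3ccc(F)cc3C(F)(F)F)CC2)nn1`: 0.2 h
- compound 3, `N#Cc1ncccc1S(=O)(=O)N1CCN(c2ccc(C(=O)NCc3ccc(F)cc3)nn2)CC1`: 0.0833 h

Compound 3 stands lowest of the three numbers. Its nearest neighbour is compound 2, and the step of a 2.4-fold lower number from compound 2 to compound 3 (0.38 log units; beyond the scatter) lies beyond the scatter; the step of a 6.2-fold lower number from compound 1 to compound 3 (0.79 log units; beyond the scatter) is larger still. Within the sulfonyl aryl group, the step of a 2.6-fold lower number from compound 1 to compound 2 (0.41 log units; beyond the scatter) shows that even a small change there moved the number by a modest amount.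

Compound 4, `Nc1ncccc1S(=O)(=O)N1CCN(c2ccc(C(=O)NCc3ccc(F)cc3)nn2)CC1`, differs from compound 3 by amino in place of cyano on an aromatic carbon. For the measured compounds named here, no measured pair shows this exact change, so the expectation rests on how far the sulfonyl aryl changes have moved the numbers so far. Those steps were all modest and all downward toward compound 3, which already sits at the bottom. For compound 4 the author expects a step of a 1.4-fold higher number from compound 3 to compound 4 (0.16 log units; within the scatter), small and uncertain in direction, most likely a slight rise. The estimate for compound 4 is therefore 0.12 h, with a range from 0.05 h to 0.3 h.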

Compound 4, half-life: 0.317 h
Compound 4: middle estimate off by 2.6-fold (0.42 log units), on the low side, and the stated range ends below it.
By their numbers in this assay, from the lowest: compound 3; then compounds 2, 4 and 1 (each within the scatter of the next, the first and the last beyond it).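

In this assay, the carbon next to the ring nitrogen proves sensitive to which group it carries: a 3.8-fold higher number from compound 3 to compound 4 (0.58 log units; beyond the scatter), the first upward step shown among the sulfonyl aryl changes. The low number of compound 3 therefore does not follow from the six-membered aromatic ring with 1 nitrogen alone, since that ring is also present in compound 4. The 2-aminopyridin-3-yl group also matches both trifluoromethyl-bearing aryl groups within the scatter, with a 1.6-fold higher number from compound 2 to compound 4 (0.20 log units; within the scatter) and a 1.6-fold lower number from compound 1 to compound 4 (0.21 log units; within the scatter).

Nothing measured here explains why the amino group and the cyano group differ. As far as these compounds go, it remains open what a methylamino or methoxy group on this carbon would give, and whether amino in place of cyano would have a similar effect on another sulfonyl aryl group.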